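Methoxy on the benzyl ring across two chain lengths

A few compounds are considered here, and "the series" means these few. Any claim that something is new, unique, unknown or untested is made for them only; others in the source may bear on it.

compound 1, `COc1cc2sn(CCCCN(C)Cc3ccccc3)c(=O)c2cc1OC`, in an assay on isolated protein for inhibition of Amine oxidase [flavin-containing] B (Homo sapiens), read by fluorescence, with a stated time of 30 min; a lower number here means a stronger inhibitor, a higher number a weaker inhibitor: 19700 nM
compound 2, `COc1ccccc1CN(C)CCCCn1sc2cc(OC)c(OC)cc2c1=O`, in this assay: 19200 nM
compound 3, `COc1cc2sn(CCCCCCN(C)Cc3ccccc3)c(=O)c2cc1OC`, in this assay: 13200 nM

Compound 1 and compound 2 differ in one place, (methoxy in place of hydrogen on an aromatic carbon). The step of a 1.0-fold lower number from compound 1 to compound 2 (0.01 log units; within the scatter) leaves the number where it was. Among the measured compounds shown here, compound 3 carries the same benzyl group as compound 1 on a longer chain; the difference between the two cores is not broken down here, and the two values show only that compound 3 and compound 1 sit within the scatter of each other, as do compound 3 and compound 2. Among the three measured compounds no one is separated from the others by a step beyond the scatter, so no ordering is claimed.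

Compound 4, `COc1ccccc1CN(C)CCCCCCn1sc2cc(OC)c(OC)cc2c1=O`, has not yet been measured in this assay. It differs from compound 3 by methoxy in place of hydrogen on an aromatic carbon. The place is the same in both descriptions, so this is the same change that was made from compound 1 to compound 2. The step of a 1.0-fold lower number from compound 3 to compound 4 (0.01 log units; within the scatter) is expected to be essentially flat, because a 1.0-fold lower number from compound 1 to compound 2 (0.01 log units; within the scatter) was flat when the same change was made on the shorter chain. On that basis compound 4 is estimated at 13000 nM in this assay. For the measured compounds named here, the range for compound 4 is expected to run from 7000 nM to 25000 nM, a width that allows for the usual scatter around the single precedent.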

Compound 4, half-maximal inhibitory concentration: 13700 nM
Beside the measured number, compound 4's estimate is 1.1-fold (0.02 log units) below it, within the range that was stated.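

In this assay, the move from benzyl to 2-methoxybenzyl on the longer chain gives a 1.0-fold higher number from compound 3 to compound 4 (0.02 log units; within the scatter), so the change leaves the number where it stood on this core as well. Set beside each other, the two steps agree: the same change on two cores in this assay, a 1.0-fold lower number (0.01 log units; within the scatter) from compound 1 to compound 2 and a 1.0-fold higher number (0.02 log units; within the scatter) from compound 3 to compound 4, 1.1-fold (0.03 log units) apart, within the scatter of two such steps. Among the compounds shown here, this shows that, across these two pairs, the methoxy change carries from one core to the other as a step within the scatter, but it rests on only two pairs, shows nothing about any core beyond them, and, with neither step beyond the scatter, gives no information on how the group acts.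

The compounds shown leave open whether a different group at the same place on the benzyl ring, such as fluorine, a hydroxyl or a nitrile, or a methoxy on another carbon of that ring, would give a step beyond the scatter. Also open, as far as these compounds go, is whether the methoxy change would remain flat on a longer chain, or with an ethyl group in place of the methyl on the amine.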